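This account rests on a few compounds, and the source may have more. Where it says the series, first, only, none or still open, it means among the compounds named here.

Notes on the series in an assay on isolated protein for inhibition of high affinity 3',5'-cyclic-AMP phosphodiesterase 7A (Homo sapiens), read by cAMP accumulation, with a stated time of 20 min; on this read-out lower numbers stand for stronger inhibition and higher numbers for weaker inhibition. Compound 1 `CCCCCn1c(-c2ccco2)nc2c(NCc3ccccc3)ccnc21` returns a limit of this assay rather than a number: compound 1 gives > 200000 nM. Compound 2 `CCCCCn1c(-c2ccccc2)nc2c(NCCCO)ccnc21` likewise returns only a limit in this assay, with compound 2 at > 200000 nM. Compound 2 therefore stands at the limit, and no order between compound 2 and compound 1 can be read, as the limit of > 200000 nM in this assay, at which 2 of the 2 values shown sit, shows. Compound 3 `CCCCCn1c(-c2ccco2)nc2c(NCCCO)ccnc21` is not yet measured; it differs from compound 2 in one place, with furan-2-yl in place of phenyl on an aromatic carbon. Within the data shown here, no step between two measured compounds is available to size this change. Compound 1, which already carries the furan-2-yl group and gives a limit of > 200000 nM in this assay, offers no sign that this ring brings a number inside the measured range. For compound 3 the expected step is a step that the limit leaves unreadable from compound 2 to compound 3, which means none beyond the scatter and most probably a further limit. Compound 3 is thus estimated at 300000 nM, with a range from 100000 nM to 1000000 nM.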

Compound 3, half-maximal inhibitory concentration: 63600 nM
Compound 3: middle estimate off by 4.7-fold (0.67 log units), on the high side; measured number below the stated range.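

In this assay, furan-2-yl in place of phenyl on an aromatic carbon gives an at least 3.1-fold lower number from compound 2 to compound 3 (0.49 log units; beyond the scatter), so this position, between two ring nitrogen atoms, can move the read-out when the 3-hydroxypropyl amine side is kept. With furan-2-yl held, 2-hydroxyethyl in place of phenyl on a saturated chain carbon bound to a nitrogen on an aromatic ring gives an at least 3.1-fold lower number from compound 1 to compound 3 (0.49 log units; beyond the scatter), so the furan-2-yl ring does not yield a number on its own and the result depends on the group on the other side as well. Both steps are minimum sizes, and their full size cannot be read because the starting compounds sit at a limit of the assay: the limit of > 200000 nM in this assay, at which 2 of the 3 values shown sit.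

As far as these compounds go, it remains open whether the step follows the ring oxygen or the smaller ring, a question that thiophen-2-yl on the same carbon would address. Also open, from the compounds shown here alone, is whether the hydroxyl end of the chain takes part, which an amine or a carboxylic acid at that end would test, and whether any such group brings compound 3, at 63600 nM, much further down.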